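This account rests on a few compounds, and the source may have more. Where it says the series, first, only, none or still open, it means among the compounds named here.

Of the compounds shown here, three sharing one core have been measured in an assay on isolated protein for inhibition of solute carrier family 22 member 12 (Homo sapiens), tested at 3 uM; a higher number here means more inhibition at the concentration tested (going by the name of the read-out), a lower number less inhibition. Compound 1 `CCc1cc(C(=O)N2CC=CC2)cc(C#N)c1O` gives 54%. Compound 2 `N#Cc1cc(C(=O)N2CC=CC2)cc(I)c1O` gives 79%. Compound 3 `N#Cc1cc(C(=O)N2CC=CC2)cc(C(F)(F)F)c1O` gives 83%. Compound 3 thus stands highest of the three numbers, yet its gap to compound 2 lies within the scatter, so the two cannot be ranked against each other; only compound 1 stands clearly apart, as the steps of a number 25 percentage points higher from compound 1 to compound 2 (beyond the scatter) and a number 29 percentage points higher from compound 1 to compound 3 (beyond the scatter) show, while a number 4 percentage points higher from compound 2 to compound 3 (within the scatter).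

Compound 4 `N#Cc1cc(C(=O)N2CCC2)cc(C(F)(F)F)c1O` has not yet been measured. It differs from compound 3 in one place: a group of 4 heavy atoms (3 carbon, 1 nitrogen; one four-membered non-aromatic ring with 1 hetero atom) in place of a group of 5 heavy atoms (4 carbon, 1 nitrogen; one five-membered non-aromatic ring with 1 hetero atom), on a carbonyl carbon. Going by the values given here, none of the measured steps bears on this change: each of them swaps the group on an aromatic carbon, whereas the change to compound 4 keeps that trifluoromethyl and alters the ring on the carbonyl carbon. The measured steps therefore give no guide to direction, and the modest size of those that were beyond the scatter suggests no large swing should be expected from a change of one ring atom. The expectation is that compound 4 keeps a number close to that of compound 3, with a step of a number 7 percentage points lower from compound 3 to compound 4 (within the scatter) that is expected to stay within the scatter. Compound 4 is thus estimated at 76% in this assay, within a range from 55% to 92%.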

Compound 4, a percentage reported as inhibition, at one concentration (the size of the read-out at that concentration, not a potency): 75%
Compound 4: middle estimate off by 1 percentage points, on the high side; measured number inside the range.
By their numbers in this assay, from the lowest: compound 1; then compounds 4, 2 and 3 (each within the scatter of the next).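

In this assay, going by these compounds alone, this is the first measured change on the carbonyl carbon, and swapping the five-membered ring with its double bond for azetidin-1-yl gives a number 8 percentage points lower from compound 3 to compound 4 (within the scatter), so compound 3 and compound 4 cannot be ranked against each other. Within the data shown here, the ring on the carbonyl carbon can therefore lose one ring atom and its double bond together, with the trifluoromethyl kept, without a change that stands clear of the scatter, whereas the earlier steps beyond the scatter all came from swapping the ethyl group on an aromatic carbon. The data shown offer no measurement that explains why this change leaves the reading within the scatter.

Because ring size and the double bond changed together, the pair cannot separate their contributions; a saturated pyrrolidin-1-yl group on the same carbonyl carbon would address that directly. On these data alone, it also remains open whether a larger ring such as piperidin-1-yl, a ring with a second hetero atom such as morpholin-4-yl, or an open-chain diethylamino group would hold the reading at this position.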